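A few compounds are considered here, and "the series" means these few. Any claim that something is new, unique, unknown or untested is made for them only; others in the source may bear on it.

Measured compounds:
Compound 1 `CC(=O)N[C@@H]1[C@@H](OC(C)=O)[C@H](OC(C)=O)[C@@H](COC(C)=O)O[C@H]1NC(=S)NCCN([C@@H](C(=O)O)C(C)C)S(=O)(=O)c1ccc(-c2ccccc2)cc1` gives 1200 nM in an assay on isolated protein for inhibition of matrix metalloproteinase-9 (Homo sapiens), read by fluorescence, with stated times of 3 h, 10 s and 15 min; on this read-out lower numbers stand for stronger inhibition and higher numbers for weaker inhibition.
Compound 2 `CC(=O)OC[C@H]1O[C@@H](NC(=S)NCCN([C@@H](C(=O)O)C(C)C)S(=O)(=O)c2ccc(-c3ccccc3)cc2)[C@H](OC(C)=O)[C@@H](OC(C)=O)[C@@H]1OC(C)=O` gives 880 nM in this assay.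
Compound 3 `CO[C@@H]1O[C@H](CN([C@@H](C(=O)O)C(C)C)S(=O)(=O)c2ccc(-c3ccccc3)cc2)[C@@H](OC(C)=O)[C@H](OC(C)=O)[C@H]1NC(C)=O` gives 1240 nM in this assay.

Compounds 1 and 2 share one core, and the change between them is acetoxy in place of acetamido on a saturated ring carbon. Its effect is a 1.4-fold lower number from compound 1 to compound 2 (0.13 log units; within the scatter). Compound 3 rests on a different core; how the two cores differ is not broken down here. Its number in this assay sits near those of compound 1 and compound 2, and the three values stand within the scatter of one another, so none of them can be set apart.

Compound 4 `CO[C@@H]1O[C@H](CN([C@@H](C(=O)O)C(C)C)S(=O)(=O)c2ccc(-c3ccccc3)cc2)[C@@H](OC(C)=O)[C@H](OC(C)=O)[C@H]1OC(C)=O` has not yet been measured. It arises from compound 3 by acetoxy in place of acetamido on a saturated ring carbon. Within the data shown here, this is the same kind of change as the one from compound 1 to compound 2, though the surroundings differ: in compound 1 the site is next to the ring atom that bears a large group and three ring bonds from the ring atom that bears an acetoxymethyl group, whereas in compound 3 it is next to the ring atom that bears a methoxy group and three ring bonds from the ring atom that bears a large group.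

Because a 1.4-fold lower number from compound 1 to compound 2 (0.13 log units; within the scatter) stayed within the scatter, the step from compound 3 to compound 4 is expected to be about as small, a 1.3-fold lower number from compound 3 to compound 4 (0.12 log units; within the scatter). Compound 4 is therefore estimated at 950 nM in this assay, expected to fall between 450 nM and 2000 nM.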

Compound 4, half-maximal inhibitory concentration: 2600 nM
For compound 4 the middle estimate is 2.7-fold (0.44 log units) below the measured one; measured number above the stated range.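

In this assay, acetoxy in place of acetamido on a saturated ring carbon gives a 2.1-fold higher number from compound 3 to compound 4 (0.32 log units; beyond the scatter), and set beside the earlier step, the same change does not carry over unchanged from one core to the other: the same change on two cores in this assay, a 1.4-fold lower number (0.13 log units; within the scatter) from compound 1 to compound 2 and a 2.1-fold higher number (0.32 log units; beyond the scatter) from compound 3 to compound 4, 2.9-fold (0.46 log units) apart, beyond the scatter of two such steps

In this small series, then, the step measured on the core of compound 1 is not a reliable guide to the step on the core of compound 3, since the change stays within the scatter on one core and goes beyond it on the other. Among these compounds, the result does not show why the two steps part, nor whether other cores would follow either one, as it rests on only two pairs, and these differ both in the core and in the surroundings of the changed ring carbon, which the data cannot separate.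

The compounds shown leave open how a hydroxyl or an amine in place of acetamido on this ring carbon would read on either core. They also leave open whether a longer chain in place of the methoxy group on the core of compound 3 would alter the size of this step.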